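Ester in place of alcohol: expected tolerance of compound 4

The source may hold more compounds than are shown below. What is called first, only, known or untested is meant among the compounds shown, and "the series" means these compounds.

Three compounds were tested in an ADME assay on Vero cells (Chlorocebus sabaeus) for cytotoxicity, read by fluorescence and resazurin assay, with a stated time of 3 days; a higher number here means that more compound is tolerated, a lower number that less compound is tolerated. Compound 1 `CC1(C)O[C@H]2O[C@H]([C@@H](CCO)n3cnc4c(N)ncnc43)[C@H](Oc3ccccc3[N+](=O)[O-])[C@H]2O1` gives 51800 nM. Compound 2 `CCOC(=O)C[C@@H]([C@H]1O[C@@H]2OC(C)(C)O[C@@H]2[C@H]1OCc1ccccc1)n1cnc2c(NCc3ccccc3)ncnc21` gives 57500 nM, and compound 3 `CC1(C)O[C@H]2O[C@H]([C@H](CCO)n3cnc4c(NCc5ccccc5)ncnc43)[C@H](OCc3ccccc3)[C@H]2O1` gives 61200 nM. Compounds 2 and 3 differ by one change, (ethoxycarbonyl in place of hydroxymethyl on a saturated chain carbon, two bonds along the chain from an aromatic nitrogen and a saturated ring carbon), which gave a step of a 1.1-fold lower number from compound 3 to compound 2 (0.03 log units; within the scatter). Compound 4 `CCOC(=O)C[C@H]([C@H]1O[C@@H]2OC(C)(C)O[C@@H]2[C@H]1Oc1ccccc1[N+](=O)[O-])n1cnc2c(N)ncnc21` is not yet measured; it is related to compound 1 by the same change, (ethoxycarbonyl in place of hydroxymethyl on a saturated chain carbon, two bonds along the chain from an aromatic nitrogen and a saturated ring carbon). The difference between the core of compound 1 and that of compound 3 is not broken down here. Because the step of a 1.1-fold lower number from compound 3 to compound 2 (0.03 log units; within the scatter) stayed within the scatter, a similar outcome is expected from compound 1 to compound 4, namely a 1.0-fold lower number from compound 1 to compound 4 (0.02 log units; within the scatter). Compound 4 is therefore estimated at 50000 nM in this assay, with a likely range from 28000 nM to 90000 nM.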

Compound 4, half-maximal cytotoxic concentration: 119000 nM
Compound 4: middle estimate off by 2.4-fold (0.38 log units), on the low side; measured number above the stated range.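

In this assay, ethoxycarbonyl in place of hydroxymethyl gave a 2.3-fold higher number from compound 1 to compound 4 (0.36 log units; beyond the scatter). Set beside the earlier step, this one does not stand apart from it by more than the scatter allows: the same change on two cores in this assay, a 1.1-fold lower number (0.03 log units; within the scatter) from compound 3 to compound 2 and a 2.3-fold higher number (0.36 log units; beyond the scatter) from compound 1 to compound 4, 2.4-fold (0.39 log units) apart, within the scatter of two such steps. The two steps therefore give no sign that the change behaves differently on the two cores, but two pairs cannot show that it carries over unchanged across the series.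

The compounds shown leave open how a carboxylic acid or an amide would read in this assay in place of ethoxycarbonyl on that saturated chain carbon. They also leave open whether a longer chain there would follow the same course.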